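The source may hold more compounds than are shown below. What is called first, only, known or untested is meant among the compounds shown, and "the series" means these compounds.

Working notes on the series. Of the compounds shown here, two of this set have been measured in an assay for inhibition of 3-hydroxy-3-methylglutaryl-coenzyme A reductase (Rattus norvegicus); on this read-out higher numbers stand for weaker inhibition and lower numbers for stronger inhibition. Compound 1 `Cc1cc(-c2ccc(Cl)cc2)c(/C=C/[C@@H]2C[C@@H](O)CC(=O)O2)c(C)n1` gives 94 nM in this assay. Compound 2 `CCc1nc(-c2ccccc2)cc(-c2ccc(F)cc2)c1/C=C/[C@@H]1C[C@@H](O)CC(=O)O1` gives 40 nM in this assay, the lower of the two numbers shown so far; the gap between compound 2 and compound 1 is beyond the usual scatter, so compound 2 stands as the stronger inhibitor of the two measured compounds.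

Compound 3 `CC(C)(C)c1nc(-c2ccccc2)cc(-c2ccc(F)cc2)c1/C=C/[C@@H]1C[C@@H](O)CC(=O)O1` has not yet been measured in this assay. It is derived from compound 2 by a single alteration: tert-butyl in place of ethyl on an aromatic carbon. Among the measured compounds shown here, no measured pair shows the effect of such a change, so there is no comparable step to lean on. The alteration is small and adds only two carbon atoms without any ring, donor, acceptor or charge. The expectation is that compound 3 stays close to compound 2, with any step from compound 2 to compound 3 of about a 1.4-fold higher number from compound 2 to compound 3 (0.14 log units; within the scatter), that is, not clearly beyond the scatter. Compound 3 is estimated at 55 nM in this assay, with a likely range from 20 nM to 160 nM.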

Compound 3, half-maximal inhibitory concentration: 18 nM
Compound 3: middle estimate off by 3.1-fold (0.49 log units), on the high side, and the stated range ends above it.
By their numbers in this assay, from the lowest: compound 3; then compound 2; then compound 1.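

In this assay, among the compounds shown here, tert-butyl in place of ethyl on the aromatic carbon next to the ring nitrogen and ortho to the 2-(4-hydroxy-6-oxooxan-2-yl)ethenyl group gives a 2.2-fold lower number from compound 2 to compound 3 (0.35 log units; beyond the scatter), and this is the first step that can be read between compounds differing in one place. The position therefore takes the larger tert-butyl group with no loss of inhibition, and the modest step runs towards stronger inhibition, although this rests on a single pair. Nothing measured on either group bears on this result, so the step stands without an explanation.

The compounds shown leave open how the number changes across other groups at this position: one pair cannot tell what isopropyl, a cyclopropyl ring or an amine would do there. Also open, on these data alone, is whether the step from ethyl to tert-butyl would carry over with a different group in place of the phenyl group, such as a methoxyphenyl group or a carboxylic acid.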